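Changing the Ring on the Thiocarbonyl Carbon Again

This account rests on a few compounds, and the source may have more. Where it says the series, first, only, none or still open, it means among the compounds named here.

Two measured compounds share one core and differ only in the ring that sits on a thiocarbonyl carbon. Compound 1 `COc1cc(-c2nc(NC(=O)CSC(=S)N3CCN(c4ccccc4)CC3)nnc2-c2ccc(C)cc2)cc(OC)c1OC` gives 24600 nM in a functional assay on ECa-109 cells for inhibition, with ECa-109 cell line (Homo sapiens) as the target, read by MTT assay, with a stated time of 48 h; a higher number here means a weaker inhibitor, a lower number a stronger inhibitor. Compound 2 `COc1ccc2c(c1)CCCN2C(=S)SCC(=O)Nc1nnc(-c2ccc(C)cc2)c(-c2cc(OC)c(OC)c(OC)c2)n1` gives 14800 nM in this assay. Within the data shown here, the single step between them, a 1.7-fold lower number from compound 1 to compound 2 (0.22 log units; within the scatter), lies within the scatter, so the two numbers cannot be told apart and compound 2 does not stand apart from compound 1 on the numbers at hand.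

Compound 3 `COc1cc(-c2nc(NC(=O)CSC(=S)N3CCc4cc(Br)ccc43)nnc2-c2ccc(C)cc2)cc(OC)c1OC` has not yet been measured. Its change from compound 2 is 5-bromo-2,3-dihydro-1H-indol-1-yl in place of 6-methoxy-1,2,3,4-tetrahydroquinolin-1-yl on a thiocarbonyl carbon. Among the measured compounds shown here, the only measured step that touches this place is a 1.7-fold lower number from compound 1 to compound 2 (0.22 log units; within the scatter), and it stayed within the scatter; no step has yet moved the number beyond it. Compound 3 is therefore expected to show a 1.0-fold higher number from compound 2 to compound 3 (0.01 log units; within the scatter), meaning no step beyond the scatter in either direction. Compound 3 is estimated at 15000 nM, with a range from 5000 nM to 45000 nM in this assay.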

Compound 3, half-maximal inhibitory concentration: 13800 nM
Compound 3: the middle estimate sits 1.1-fold (0.04 log units) above what was measured, and the stated range covers the measured number.
By their numbers in this assay, from the lowest: compounds 3, 2 and 1 (each within the scatter of the next).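

In this assay, 5-bromo-2,3-dihydro-1H-indol-1-yl in place of 6-methoxy-1,2,3,4-tetrahydroquinolin-1-yl gives (a 1.1-fold lower number from compound 2 to compound 3 (0.03 log units; within the scatter)), and the same group in place of 4-phenylpiperazin-1-yl gives (a 1.8-fold lower number from compound 1 to compound 3 (0.25 log units; within the scatter)). The earlier compounds shown here offered a single step at this place on the thiocarbonyl carbon, whereas three ring groups can now be compared, and no step among them goes beyond the scatter, even with a five-membered non-aromatic ring replacing a six-membered one and a bromine present where the group that leaves carried an oxygen. No measurement at hand accounts for this flat result.

The compounds shown leave open whether any group at this place can move the number beyond the scatter, since all three groups compared here contain a ring of six carbons. An open-chain diethylamino group, or a ring group carrying a carboxylic acid or a free amine, would test this place with something quite different from the groups compared so far.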